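The source may report more compounds than this note shows. Statements on the series, on what has been measured and on what is new or still open speak of the compounds shown alone.

In an assay on CHO cells for displacement of a labelled ligand from Alpha-2C adrenergic receptor (Homo sapiens) (on this read-out higher numbers stand for weaker inhibition and lower numbers for stronger inhibition), compound 1, with the structure `CC(Oc1ccccc1-c1ccccc1)C1=NCCO1`, gives 5890 nM, the highest of the three numbers recorded so far. Compound 3, with the structure `CC(Oc1ccccc1-c1ccccn1)C1=NCCN1`, gives 1260 nM, and compound 2, with the structure `CC(Nc1ccccc1-c1ccccc1)C1=NCCN1`, gives 708 nM; both of these numbers stand lower than that of compound 1, and the gap to each is beyond the usual scatter, so compound 1 is the weakest inhibitor among the three measured compounds. Compound 4, with the structure `CC(Oc1ccccc1-c1ccccc1)C1=NCCC1`, has not yet been measured. It differs from compound 1 in one place, as follows: a group of 5 heavy atoms (4 carbon, 1 nitrogen; one five-membered non-aromatic ring with 1 hetero atom) in place of a group of 5 heavy atoms (3 carbon, 1 nitrogen, 1 oxygen; one five-membered non-aromatic ring with 2 hetero atoms), on a saturated chain carbon bound to an oxygen on an aromatic ring and a saturated chain carbon. Among the measured compounds shown here, no step of this kind between measured compounds is available, so the expectation rests on the change itself and on the numbers of compounds 1, 2 and 3. The group that enters keeps the five-membered non-aromatic ring with its one double bond outside aromatic rings, but carries one hetero atom where the leaving group carried two, and one hydrogen-bond acceptor where the leaving group carried two. The expected step in this assay is a modest weakening, a 1.5-fold higher number from compound 1 to compound 4 (0.18 log units; within the scatter), since compound 1 already gives 5890 nM at the weak end of the set. Compound 4 is therefore expected to give about 9000 nM, within a range from 2500 nM to 30000 nM.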

Compound 4, inhibition constant: 5890 nM
Estimate against measurement, compound 4: 1.5-fold (0.18 log units) above; the measured number falls inside the stated range.
By their numbers in this assay, from the lowest: compounds 2 and 3 (each within the scatter of the next); then compounds 1 and 4 (each within the scatter of the next).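

Replacing the five-membered ring with two hetero atoms by the five-membered ring with one hetero atom, on a saturated chain carbon bound to an oxygen on an aromatic ring and a saturated chain carbon, gives no change at the digits printed from compound 1 to compound 4 (within the scatter) in this assay. Among the compounds shown here, this is the first comparison in the set that isolates a single change, and it shows that in this one pair the ring oxygen, along with the hydrogen-bond acceptor count that falls with its loss, can be exchanged for carbon without a measurable shift in the number. No measurement is available that would explain this outcome.

The compounds shown leave open whether a different group at this place, such as an open-chain amine, a carboxylic acid or a six-membered ring, would move the number in this assay. A single pair also cannot say whether the same exchange would leave the number unchanged on another core, such as that of compound 2 or compound 3, where neither compound yet has a partner differing from it in one place only.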